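A few compounds are considered here, and "the series" means these few. Any claim that something is new, unique, unknown or untested is made for them only; others in the source may bear on it.

Measured compounds:
- compound 1 `COc1ccccc1-c1sc(N)c(C(=O)c2ccc(Cl)cc2)c1CC(C)(C)C`: 1%
- compound 2 `Cc1cccc(-c2sc(N)c(C(=O)c3ccc(Cl)cc3)c2CC(C)(C)C)c1`: 1%

In an assay on CHO cells for displacement of a labelled ligand from adenosine receptor A3 (Homo sapiens), read by scintillation counting, tested at 10 uM (on this read-out lower numbers stand for less inhibition and higher numbers for more inhibition at the one concentration tested (going by the name of the read-out)), compound 1 gives 1% and compound 2 gives 1%; the step of no change at the digits printed from compound 1 to compound 2 (within the scatter) shows no change at the digits recorded. Among the compounds with values here, compound 2 therefore stands level with compound 1, both at the floor of the inhibition scale, with compound 1 its only neighbour.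

Compound 3 `Cc1ccccc1-c1sc(N)c(C(=O)c2ccc(Cl)cc2)c1CC(C)(C)C` differs from compound 2 in one place: 2-methylphenyl in place of 3-methylphenyl on an aromatic carbon. Within the data shown here, the only measured step that bears on a change of the aryl group at this position is no change at the digits printed from compound 1 to compound 2 (within the scatter), and it was flat: a 3-methylphenyl for a 2-methoxyphenyl left the read-out unchanged. Nothing in the two measured compounds suggests that a 2-methylphenyl at the same place would lift the inhibition above the scatter, so the expected step is a number 2 percentage points higher from compound 2 to compound 3 (within the scatter), no change beyond scatter. Compound 3 is therefore estimated at 3%, with a range from 0% to 15%.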

Compound 3, a percentage reported as inhibition, at one concentration (the size of the read-out at that concentration, not a potency): 1%
Compound 3: middle estimate off by 2 percentage points, on the high side, within the range that was stated.
By their numbers in this assay, from the lowest: compounds 1, 2 and 3 (each within the scatter of the next).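

In this assay the shift of the methyl on the phenyl ring gives no change at the digits printed from compound 2 to compound 3 (within the scatter) and so does not separate 3-methylphenyl from 2-methylphenyl on this aromatic carbon next to the ring sulfur. The exchange of 2-methoxyphenyl for 2-methylphenyl gives no change at the digits printed from compound 1 to compound 3 (within the scatter) and adds a direct reading of methyl in place of methoxy, which also leaves the read-out flat. No supporting measurement bears on why these groups read alike.

As far as these compounds go, whether an aminomethyl group or a carboxylic acid on this phenyl ring would lift the read-out remains open, as all three compounds carry only a methyl or a methoxy there. From the compounds shown here alone, the neopentyl, (4-chlorophenyl)carbonyl and amino groups are the same in all three compounds, so their contribution also remains open.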